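The source may report more compounds than this note shows. Statements on the series, on what has been measured and on what is new or still open speak of the compounds shown alone.

Measured compounds:
compound 1 `Cc1cc(C(=O)O)nn1Cc1cc(Br)ccc1OCc1ccc(Cl)cc1Cl` — in an assay on CHO-K1 cells for displacement of a labelled ligand from prostaglandin E2 receptor EP1 subtype (Homo sapiens) (a lower number here means a stronger inhibitor, a higher number a weaker inhibitor), compound 1 gives 0.132 nM
compound 2 `Cc1cc(C(=O)O)nn1Cc1cc(Br)ccc1OCc1cccc(Br)c1` — in this assay compound 2 gives 17.8 nM
compound 3 `Cc1cc(C(=O)O)nn1Cc1cc(Br)ccc1OCc1cccc(Cl)c1` — in this assay compound 3 gives 115 nM

Compound 4 `Cc1cc(C(=O)O)nn1Cc1cc(Cl)ccc1OCc1ccc(Cl)cc1Cl` is not yet measured. It differs from compound 1 by chloro in place of bromo on an aromatic carbon. The same kind of change has been measured once, as chloro in place of bromo on an aromatic carbon, where it gave a 6.5-fold higher number from compound 2 to compound 3 (0.81 log units; beyond the scatter). The cores of the two pairs differ by 2,4-dichlorophenyl in place of 3-bromophenyl on a saturated chain carbon bound to an oxygen on an aromatic ring, a difference that gave a 130-fold higher number from compound 1 to compound 2 (2.13 log units; beyond the scatter). The places are not identical: in compound 1 the carbon is meta to a large group and para to a large group, in compound 2 only meta to a large group. A smaller loss is expected, a 3.0-fold higher number from compound 1 to compound 4 (0.48 log units; beyond the scatter), because the measured precedent a 6.5-fold higher number from compound 2 to compound 3 (0.81 log units; beyond the scatter) sits on a different ring and the change here lies on the shared core. Compound 4 is estimated at 0.4 nM, between 0.1 nM and 2 nM.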

Compound 4, half-maximal inhibitory concentration: < 2000 nM
Compound 4: only a limit was reported; the forecaster's own chance of this, stated with the estimate: 0%; the middle value lies beyond the limit too.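

Compound 4 is reported only as a limit of < 2000 nM and the step from compound 1 to compound 4 cannot be read. The compounds shown leave open what chloro in place of bromo does on the core of compound 1.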